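The compounds below may be only part of what the source reports. "The series", "measured", "known", "first", "only" and "open" are said of these compounds alone.

Three compounds carry numbers in an assay on HEK293 cells for inhibition of prostaglandin E2 receptor EP2 subtype (Rattus norvegicus); on this read-out lower numbers stand for stronger inhibition and higher numbers for weaker inhibition. Compound 1 `CCCCCC(=O)c1ccc(CN(CCCCCCC(=O)O)S(C)(=O)=O)cc1` gives 636 nM. Compound 2 `CC(C)(C)c1ccc(CN(Cc2cccc(CCC(=O)O)c2)S(=O)(=O)c2ccccc2)cc1` gives 278 nM, and compound 3 `Cn1ccnc1CS(=O)(=O)N(Cc1ccc(C(C)(C)C)cc1)Cc1cccc(OCC(=O)O)c1` gives 326 nM. Compound 2 holds the lowest of the three numbers; its gap to compound 3 lies within the scatter, so no order between those two is read, while the gap to compound 1 lies beyond the scatter. Among the measured compounds shown here, no pair among the three differs in one place only, so no single step has been measured in this set.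

The next compound, compound 4 `CC(C)(C)c1ccc(CN(Cc2cccc(CCC(=O)O)c2)S(=O)(=O)c2ccccn2)cc1`, differs from compound 2 in one place: pyridin-2-yl in place of phenyl on a sulfonyl sulfur. Nothing in the measured set speaks to this exchange, and the change keeps the same ring size at the same position. The expected step from compound 2 to compound 4 in this assay is a 1.1-fold higher number from compound 2 to compound 4 (0.03 log units; within the scatter), that is, none beyond the scatter, in either direction. Compound 4 is therefore estimated at 300 nM in this assay, with a range from 120 nM to 800 nM.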

Compound 4, half-maximal inhibitory concentration: 52 nM
Compound 4: the middle estimate sits 5.8-fold (0.76 log units) above what was measured, and the stated range ends above it.
By their numbers in this assay, from the lowest: compound 4; then compounds 2, 3 and 1 (each within the scatter of the next, the first and the last beyond it).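

In this assay, among the compounds shown here, the group on the sulfonyl sulfur is not interchangeable among six-membered aromatic rings: pyridin-2-yl in place of phenyl brings a 5.3-fold lower number from compound 2 to compound 4 (0.73 log units; beyond the scatter) and is the first single step read in this set. The exchange replaces a ring of carbon only with a ring holding 1 hetero atom and 1 hydrogen-bond acceptor, with the heavy-atom count unchanged, so the ring nitrogen is the only difference between the two compounds. No measurement at hand explains the step.

The compounds shown leave open whether pyridin-3-yl, pyridin-4-yl or pyrimidin-2-yl on the sulfonyl sulfur would give a step of similar size. Also open, as far as these compounds go, is whether the same exchange holds when the propanoic acid chain of compound 2 gives way to a different acid-bearing chain.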